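Swapping hydroxymethyl for difluoromethyl on a shared core

This account rests on a few compounds, and the source may have more. Where it says the series, first, only, none or still open, it means among the compounds named here.

Measured compounds:
compound 1 `CC(=O)NCc1cccc(Cn2nc(NS(=O)(=O)c3ccc(Cl)s3)c3c(O)cccc32)c1`, 794 nM
compound 2 `CC(=O)NCc1cccc(Cn2nc(NS(=O)(=O)c3ccc(Cl)s3)c3c(CO)cccc32)c1`, 1000 nM

In an assay on isolated protein (blood) for antagonist activity at C-C chemokine receptor type 4 (Homo sapiens), read by flow cytometry, with a stated time of 30 min (a higher number here means weaker binding, a lower number tighter binding), compound 1 gives 794 nM and compound 2 gives 1000 nM. Compound 2 shows the higher of the two numbers, but the step of a 1.3-fold higher number from compound 1 to compound 2 (0.10 log units; within the scatter) lies within the scatter, so the two compounds cannot be told apart on these data.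

Compound 3 `CC(=O)NCc1cccc(Cn2nc(NS(=O)(=O)c3ccc(Cl)s3)c3c(C(F)F)cccc32)c1` has not been measured. It differs from compound 2 by difluoromethyl in place of hydroxymethyl on an aromatic carbon. Among the measured compounds shown here, the only measured step on this core, a 1.3-fold higher number from compound 1 to compound 2 (0.10 log units; within the scatter), changed the same aromatic carbon and moved the number by no more than the scatter. For the measured compounds named here, no measured step exchanges a group carrying a hydrogen-bond donor and acceptor for one carrying neither, so the direction of the step is uncertain. On this basis compound 3 is expected to sit near compound 2, giving an estimated 1200 nM in this assay, with a range from 500 nM to 3000 nM. The expected step of a 1.2-fold higher number from compound 2 to compound 3 (0.08 log units; within the scatter) is therefore small.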

Compound 3, dissociation constant: 7940 nM
Compound 3: the middle estimate sits 6.6-fold (0.82 log units) below what was measured; measured number above the stated range.
By their numbers in this assay, from the lowest: compounds 1 and 2 (each within the scatter of the next); then compound 3.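

In this assay, the aromatic carbon that carries these groups is not indifferent to what sits on it: the step of a 7.9-fold higher number from compound 2 to compound 3 (0.90 log units; beyond the scatter) shows weaker binding with difluoromethyl than with hydroxymethyl. Among the compounds shown here, the step of a 10-fold higher number from compound 1 to compound 3 (1.00 log units; beyond the scatter) points the same way, whereas hydroxy and hydroxymethyl could not be told apart, so only this third group reveals that the position can respond to a change. Nothing available here explains the weaker binding.

Hydroxymethyl has a hydrogen-bond donor and acceptor and difluoromethyl has neither, but this single exchange also brings in fluorine, so the two differences cannot be separated. A methyl group, a methoxy group or an amine on the same carbon would show how far the trend extends.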